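This account rests on a few compounds, and the source may have more. Where it says the series, first, only, none or still open, it means among the compounds named here.

Measured in a functional assay on NALM-6 cells (Homo sapiens) for cytotoxicity, with a stated time of 72 h; a lower number here means that less compound is needed, a higher number that more compound is needed for the effect:
- Compound 1 `C=C[C@@](C)(/C=C/c1ccc(O)cc1)CCC=O`: > 43400 nM (a limit)
- Compound 2 `C=C[C@@](C)(/C=C/c1ccc(O)cc1)CC/C=C(\C)C(=O)OCC`: > 43400 nM (a limit)
- Compound 3 `C=C[C@@](C)(/C=C/c1ccc(O)c(CO)c1)CCC=C(C)C`: 16400 nM

Among the compounds with values here, compound 3 gives 16400 nM, the only actual number in this small set. The readings of compound 1 and compound 2 are both (the limit of > 43400 nM in this assay, at which 2 of the 3 values shown sit).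

Compound 4 `C=C[C@@](C)(/C=C/c1ccc(O)c(/C=C/C(=O)O)c1)CCC=C(C)C` carries 2-carboxyethenyl in place of hydroxymethyl on an aromatic carbon. Within the data shown here, no measured pair in the set shows what such a change does. A small move towards a higher number in this assay is therefore expected, a 1.6-fold higher number from compound 3 to compound 4 (0.20 log units; within the scatter). For compound 4 the estimated value is 26000 nM, with an expected range from 10000 nM to 43400 nM.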

Compound 4, half-maximal effective concentration: > 43400 nM
Compound 4 ended at the assay's limit; the forecaster's own chance of this, stated with the estimate: 40%; middle value at least 1.6-fold (0.22 log units) away from the limit.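

In this assay, replacing hydroxymethyl with 2-carboxyethenyl on this aromatic carbon, ortho to a hydroxy group, gives an at least 2.6-fold higher number from compound 3 to compound 4 (0.42 log units; beyond the scatter). Within the data shown here, the set thus shows for the first time that this position responds to the group it carries, and the one measured number is lost with this change. Compound 4 gives > 43400 nM, which is a limit and not a number, and it joins the other compounds at that reading: the limit of > 43400 nM in this assay, at which 3 of the 4 values shown sit.

As far as these compounds go, how far compound 4 lies past that limit stays open. So does whether a plain carboxylic acid, an amine or a longer chain in this place would keep a measurable value.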